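The source may report more compounds than this note shows. Statements on the series, on what has been measured and on what is new or still open speak of the compounds shown alone.

Compound 1, whose structure is `COc1ccc2c(=O)c(/C=C/C(=O)Nc3ccc(Cl)cc3)coc2c1`, was tested in a functional assay (QGY7701 cells, Homo sapiens) for inhibition, read by MTT assay, with a stated time of 48 h; on this read-out lower numbers stand for stronger inhibition and higher numbers for weaker inhibition. In this assay compound 1 gives > 100000 nM, which is a limit of the assay rather than a number. The neighbouring compounds show what numbers look like on this scale: compound 2 `O=C(/C=C/c1coc2cc(O)ccc2c1=O)NCc1ccccc1` gives 63000 nM in this assay, and compound 3 `O=C(/C=C/c1coc2cc(O)ccc2c1=O)Nc1ccccc1` gives 17900 nM in this assay. For the measured compounds named here, the one measured step between them is a 3.5-fold lower number from compound 2 to compound 3 (0.55 log units; beyond the scatter).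

Compound 4 `COc1cccc(NC(=O)/C=C/c2coc3cc(OC)ccc3c2=O)c1` differs from compound 1 in one place: 3-methoxyphenyl in place of 4-chlorophenyl on an amide-type nitrogen. Going by the values given here, no measured step involves this exchange of one aryl group for another on the amide nitrogen; the only measured step, a 3.5-fold lower number from compound 2 to compound 3 (0.55 log units; beyond the scatter), concerns phenyl against benzyl, so it gives no direct guide. Compound 1 sits at the limit of > 100000 nM in this assay, at which 1 of the 3 values shown sits, so any step from it can only be read roughly. The expected step is an at least 1.2-fold lower number from compound 1 to compound 4 (0.09 log units; that floor lies within the scatter), and the estimate for compound 4 in this assay is 80000 nM, within a range from 20000 nM to 300000 nM.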

Compound 4, half-maximal inhibitory concentration: 39100 nM
Estimate against measurement, compound 4: 2.0-fold (0.31 log units) above; low and high end bracket the measured number.
By their numbers in this assay, from the lowest: compound 3; then compounds 4 and 2 (each within the scatter of the next). At a limit, above all of these: compound 1.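

In this assay, the aryl group on the amide nitrogen matters with the shared core held fixed: exchanging it gives an at least 2.5-fold lower number from compound 1 to compound 4 (0.40 log units; beyond the scatter). The earlier step compared only phenyl with benzyl, whereas this one shows that replacing one substituted phenyl with another on the same nitrogen also changes the read-out beyond the scatter. The true size of the step remains unknown, as the value for compound 1 is a limit and not a number: the limit of > 100000 nM in this assay, at which 1 of the 4 values shown sits.

The compounds shown leave open whether the change follows the loss of the 4-chlorophenyl or the arrival of the 3-methoxyphenyl, as both happen in this single exchange. They also leave open how this read-out would respond to an amine or a carboxylic acid on that phenyl ring.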